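Benzyloxy to anilino in a cytotoxicity test

The compounds below may be only part of what the source reports. "The series", "measured", "known", "first", "only" and "open" are said of these compounds alone.

In a functional assay on SEM cells (Homo sapiens) for cytotoxicity, with a stated time of 72 h (a higher number here means that more compound is needed for the effect, a lower number that less compound is needed), compound 1 `C=C[C@@](C)(/C=C/c1ccc(OCc2ccccc2)cc1)CCC=C(C)C` gives > 36600 nM as a limit and not a number. Compound 2 `C=C[C@@](C)(/C=C/c1ccc(O)c(/C=C(\C)C(=O)OCC)c1)CCC=C(C)C` gives > 36600 nM as a limit as well. Compound 1 thus stands without a number of its own (the limit of > 36600 nM in this assay, at which 2 of the 2 values shown sit), so the starting point of the step is open.

Compound 3 `C=C[C@@](C)(/C=C/c1ccc(Nc2ccccc2)cc1)CCC=C(C)C` keeps the core of compound 1 but carries anilino in place of benzyloxy on an aromatic carbon, para to a large group (anilino in place of benzyloxy on an aromatic carbon). Going by the values given here, no measured pair of compounds shows what such an exchange does in this assay, so the expectation is for no step beyond the scatter, in either direction. The expected step is a step that the limit leaves unreadable from compound 1 to compound 3 on this reading. Compound 3 is expected near 40000 nM with an estimated range of 15000 nM to 80000 nM and may well return only a limit.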

Compound 3, half-maximal effective concentration: > 36600 nM
Compound 3 was reported as a limit; the forecaster's own chance of this, stated with the estimate: 65%; the middle value is on the limit's open side.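

In this assay no step can be read from compound 1 to compound 3, because both are reported only as limits: the limit of > 36600 nM in this assay, at which 3 of the 3 values shown sit.

The compounds shown leave open whether anilino in place of benzyloxy on an aromatic carbon shifts the half-maximal effective concentration at all.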